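The source may hold more compounds than are shown below. What is called first, only, known or untested is meant among the compounds shown, and "the series" means these compounds.

Measured compounds:
- compound 1, `O=C(Nc1ccc(F)cc1)c1ccc(C(=O)O)nc1`, 16100 nM
- compound 2, `Cc1ccc(NC(=O)c2ccc(C(=O)O)nc2)cc1`, 8300 nM

In an assay on isolated protein (Gallus gallus) for inhibition of transmembrane prolyl 4-hydroxylase (Homo sapiens) (on this read-out lower numbers stand for stronger inhibition and higher numbers for weaker inhibition), compound 1 gives 16100 nM and compound 2 gives 8300 nM. Among the measured compounds shown here, compound 2 stands at the lowest of the two numbers, with compound 1 as its only neighbour; the single measured step, a 1.9-fold lower number from compound 1 to compound 2 (0.29 log units; within the scatter), is within the scatter, so the two compounds cannot be ranked against each other on this read-out.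

Compound 3, `COc1ccc(NC(=O)c2ccc(C(=O)O)nc2)cc1`, is not yet measured. It differs from compound 2 in one place: methoxy in place of methyl on an aromatic carbon. For the measured compounds named here, the one measured step that bears on this position is a 1.9-fold lower number from compound 1 to compound 2 (0.29 log units; within the scatter), which exchanged one small group for another on the same aromatic carbon and produced no change beyond the scatter. Going by the values given here, no measured step covers a methoxy group here, so there is no direct precedent. On the step from compound 2, a shift within the scatter is expected in this assay, in either direction, as a 1.1-fold lower number from compound 2 to compound 3 (0.04 log units; within the scatter). For compound 3 the expected value in this assay is 7500 nM, with a range from 2500 nM to 22000 nM.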

Compound 3, half-maximal inhibitory concentration: 21100 nM
Estimate against measurement, compound 3: 2.8-fold (0.45 log units) below; low and high end bracket the measured number.
By their numbers in this assay, from the lowest: compounds 2, 1 and 3 (each within the scatter of the next, the first and the last beyond it).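

In this assay, among the compounds shown here, the aromatic carbon para to a large group proves not to be indifferent to what it carries: a 2.5-fold higher number from compound 2 to compound 3 (0.41 log units; beyond the scatter), a modest change for methoxy in place of methyl and the only step beyond the scatter. Methoxy in place of fluoro gives a 1.3-fold higher number from compound 1 to compound 3 (0.12 log units; within the scatter), which lies within the scatter, so compound 3 cannot be ranked against compound 1, just as compound 1 cannot be ranked against compound 2, and the three values separate only at their two ends. Nothing available on these compounds accounts for the difference between methyl and methoxy at this position.

As far as these compounds go, whether an ethyl group, a hydroxyl group or an amine here would fall nearer compound 2 or compound 3 remains open, as does whether a longer chain such as ethoxy would move the number further in the same direction. From the compounds shown here alone, all three compounds share one core and differ at this one aromatic carbon, so it is also open whether the step from methyl to methoxy would carry over to a change elsewhere on the core.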